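A few compounds are considered here, and "the series" means these few. Any claim that something is new, unique, unknown or untested is made for them only; others in the source may bear on it.

Measured in a functional assay (trachea) with Cavia porcellus as the target; a higher number here means that more compound is needed for the effect, a lower number that less compound is needed:
Compound 1 `CCCn1c(=O)n(CC)c(=O)c2[nH]cnc21`: 1300 nM
Compound 2 `CCCn1cnc2c1c(=O)n(C)c(=O)n2CCC`: 5000 nM

Within the data shown here, only two numbers are available so far, and compound 2 has the higher one. In this assay, compound 2 gives 5000 nM, whereas compound 1 gives 1300 nM. This gap lies beyond the usual scatter, so more of compound 2 is needed for the same effect.

The next compound to be tested is compound 3 `CCCn1c(=O)n(C)c(=O)c2c1ncn2CCCN(C)C`. It differs from compound 2 in one place: dimethylamino in place of hydrogen on a saturated chain carbon, three bonds along the chain from an aromatic nitrogen. Dimethylamino stands in place of hydrogen on a saturated chain carbon, three bonds along the chain from an aromatic nitrogen. Put another way, propyl becomes 3-(dimethylamino)propyl.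

Among the measured compounds shown here, no pair of measured compounds shows what this kind of change does, so any forecast is tentative. A moderate move towards a higher number in this assay is expected, with the estimated change being a 2.4-fold higher number from compound 2 to compound 3 (0.38 log units; beyond the scatter). A result within the scatter of compound 2 would not be surprising. For compound 3, the estimated value is 12000 nM, with an expected range of 2500 nM to 60000 nM.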

Compound 3, half-maximal effective concentration: > 100000 nM
Compound 3: only a limit was reported; the forecaster's own chance of this, stated with the estimate: 15%; middle value at least 8.3-fold (0.92 log units) from the limit.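

In this assay compound 3 gives > 100000 nM, which is a limit and not an exact number. Even so, the change of propyl to 3-(dimethylamino)propyl gives an at least 20-fold higher number from compound 2 to compound 3 (1.30 log units; beyond the scatter), which shows that this place, a saturated chain carbon three bonds along the chain from an aromatic nitrogen, is far from indifferent to what is attached there. This is the first single-place change in the series, as the earlier compounds offered no such step, and its size is only a lower bound on the real shift: the limit of > 100000 nM in this assay, at which 1 of the 3 values shown sits.

Going by these compounds, a single step cannot separate the effect of the amine nitrogen from that of the added chain length, so it remains open whether a plain hexyl chain, which carries no nitrogen, would shift the number as strongly as 3-(dimethylamino)propyl does. Also unresolved is how a hydroxyl group or a carboxylic acid at the same place would read in this assay, and whether the shorter 2-(dimethylamino)ethyl chain would give a number that can be measured exactly rather than another limit.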